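Nitro for Fluoro on a Shared Core Against Carbonic Anhydrase 4

The compounds below may be only part of what the source reports. "The series", "measured", "known", "first", "only" and "open" are said of these compounds alone.

Compound 1 `O=C1c2cccc(F)c2C(=O)C1(O)O` and compound 3 `O=C1c2ccc(F)cc2C(=O)C1(O)O` have the same atoms joined differently; the difference between the two cores is not broken down here. In an assay on isolated protein for inhibition of carbonic anhydrase 4 (Homo sapiens), read by stopped-flow, with a stated time of 15 min (on this read-out higher numbers stand for weaker inhibition and lower numbers for stronger inhibition), compound 1 gives > 100000 nM, which is a limit of the assay. In this assay compound 3 gives > 100000 nM, also a limit. Compound 2 `O=C1c2cccc([N+](=O)[O-])c2C(=O)C1(O)O` carries the change nitro in place of fluoro on an aromatic carbon relative to compound 1, and in this assay compound 2 gives > 100000 nM, again a limit. The step that the two limits leave unreadable from compound 1 to compound 2 is therefore unreadable, as the limit of > 100000 nM in this assay, at which 3 of the 3 values shown sit, shows. Compound 4 `O=C1c2ccc([N+](=O)[O-])cc2C(=O)C1(O)O` is the same kind of change from compound 3, (nitro in place of fluoro on an aromatic carbon), though here the group sits meta to a fused ring and para to a fused ring rather than ortho to a fused ring and meta to a fused ring. Because the limit of > 100000 nM in this assay, at which 3 of the 3 values shown sit, holds for every value measured, the step that the limit leaves unreadable from compound 3 to compound 4 is expected to leave compound 4 at the limit as well. Compound 4 is estimated at 150000 nM, most likely reported only as a limit.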

Compound 4, inhibition constant: > 100000 nM
Compound 4 ended at the assay's limit (the forecaster's own chance of this, stated with the estimate: 90%); the middle value is on the limit's open side.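

No new step can be read from compound 3 to compound 4, since each gives only a limit: the limit of > 100000 nM in this assay, at which 4 of the 4 values shown sit.

The compounds shown leave open whether nitro in place of fluoro on an aromatic carbon changes inhibition at all.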